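This account rests on a few compounds, and the source may have more. Where it says the series, first, only, none or still open, it means among the compounds named here.

Compound 1, `COc1cc(-c2nnc3n2NC(c2ccco2)C(C(=O)c2ccc(C)cc2)S3)cc(OC)c1OC`: in a functional assay on A549 cells (Homo sapiens) for cytotoxicity, read by MTT assay, with a stated time of 48 h (a lower number here means a stronger inhibitor, a higher number a weaker inhibitor), compound 1 gives > 100000 nM, a limit of the assay.
Compound 2, `COc1cc(-c2nnc3n2NC(c2ccco2)C(C(=O)c2ccc(Br)cc2)S3)cc(OC)c1OC`: in this assay compound 2 gives 42100 nM.
Compound 3, `COc1cccc(C(=O)C2Sc3nnc(-c4cc(OC)c(OC)c(OC)c4)n3NC2c2ccco2)c1`: in this assay compound 3 gives > 100000 nM, again a limit of the assay.

Compound 3 therefore stands at the upper edge of what the numbers can show, sharing that position with compound 1 (the limit of > 100000 nM in this assay, at which 2 of the 3 values shown sit). Compound 4, `COc1cc(-c2nnc3n2NC(c2ccco2)C(C(=O)c2ccccc2)S3)cc(OC)c1OC`, is not yet measured. It differs from compound 3 in one place: hydrogen in place of methoxy on an aromatic carbon. Going by the values given here, the steps that bear on the aryl group at the carbonyl carbon are an at least 2.3-fold higher number from compound 2 to compound 3 (0.37 log units; beyond the scatter), which is at least modest, a step that the two limits leave unreadable from compound 1 to compound 3, whose size cannot be read, and an at least 2.3-fold lower number from compound 1 to compound 2 (0.37 log units; beyond the scatter). Two of the three measured compounds sit at the limit, and the only one that reads as a number, compound 2, remains weak. The step from (3-methoxyphenyl)carbonyl to benzoyl is expected to give a number no higher from compound 3 to compound 4 (the limit leaves the size open), that is, no change that the scatter would separate. Compound 4 is thus estimated at 100000 nM, most likely reported again as a limit, within 30000 nM to 300000 nM.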

Compound 4, half-maximal inhibitory concentration: 33400 nM
Compound 4: the middle estimate sits 3.0-fold (0.48 log units) above what was measured; measured number inside the range.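

Hydrogen in place of methoxy gives an at least 2.9-fold lower number from compound 3 to compound 4 (0.47 log units; beyond the scatter), and hydrogen in place of methyl gives an at least 2.9-fold lower number from compound 1 to compound 4 (0.47 log units; beyond the scatter), so the unsubstituted benzoyl compound gives a readable number where these two substituted compounds give only a limit. Hydrogen in place of bromo gives a 1.3-fold lower number from compound 2 to compound 4 (0.10 log units; within the scatter), within the scatter, so compound 2 goes against any reading that a group on this ring costs activity, and the earlier gain of bromo over methyl now reads as no gain over hydrogen. Going by these compounds, the size of the methyl and methoxy steps stays open at the top of the range: the limit of > 100000 nM in this assay, at which 2 of the 4 values shown sit.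

The compounds shown leave open whether any group on this ring can separate from hydrogen in the stronger direction. An amine, a carboxylic acid or a longer chain such as ethoxy at this place would test that.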